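From methoxy to dimethylamino on one aromatic carbon

The source may hold more compounds than are shown below. What is called first, only, known or untested is meant among the compounds shown, and "the series" means these compounds.

Compound 1 `COc1cccc(C(=O)/C=C/c2ccccc2)c1OC` gives 1670 nM
Compound 2 `COc1ccccc1C(=O)/C=C/c1ccccc1` gives 2230 nM

In a functional assay for inhibition, with Homo sapiens as the target (on this read-out higher numbers stand for weaker inhibition and lower numbers for stronger inhibition), compound 2 has only compound 1 for comparison, and the two values lie within the scatter of each other. Compound 3 `CN(C)c1ccccc1C(=O)/C=C/c1ccccc1` has dimethylamino in place of methoxy on an aromatic carbon, ortho to a large group (dimethylamino in place of methoxy on an aromatic carbon). For the measured compounds named here, the only measured step (a 1.3-fold higher number from compound 1 to compound 2 (0.13 log units; within the scatter)) puts hydrogen in place of methoxy and involves no dimethylamino, so it is just a loose guide. No change beyond the scatter is therefore expected (a 1.1-fold higher number from compound 2 to compound 3 (0.05 log units; within the scatter)). The estimated value for compound 3 is 2500 nM (expected range 800 nM to 8000 nM).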

Compound 3, half-maximal inhibitory concentration: 1770 nM
Estimate against measurement, compound 3: 1.4-fold (0.15 log units) above; low and high end bracket the measured number.
By their numbers in this assay, from the lowest: compounds 1, 3 and 2 (each within the scatter of the next).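

In this assay, dimethylamino in place of methoxy on this aromatic carbon, ortho to a large group, gives a 1.3-fold lower number from compound 2 to compound 3 (0.10 log units; within the scatter) and so stays within the scatter. This position therefore takes dimethylamino as well as methoxy without a clear difference in the read-out, whereas the earlier step covered only hydrogen in place of methoxy. No evidence is available that would explain this result.

From the compounds shown here alone, whether a carboxylic acid or a longer chain such as butoxy on this carbon would read the same remains open.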